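The compounds below may be only part of what the source reports. "The series", "measured", "known", "first", "only" and "open" are said of these compounds alone.

Measured compounds:
Compound 1, `Cc1ccc(N2CCN(c3cc(C(F)(F)F)ccc3CNC(=O)C(C)c3ccc(NS(C)(=O)=O)c(F)c3)CC2)cc1` — 0.7 nM
Compound 2, `CCCCCCOc1cc(C(C)(F)F)ccc1CNC(=O)C(C)c1ccc(NS(C)(=O)=O)c(F)c1` — 0.8 nM
Compound 3, `CCCCSc1cc(C(F)(F)F)ccc1CNC(=O)C(C)c1ccc(NS(C)(=O)=O)c(F)c1` — 1.9 nM

All three were tested in an assay on CHO cells for antagonist activity at transient receptor potential cation channel subfamily V member 1 (Homo sapiens), read by FLIPR; a higher number here means a weaker inhibitor, a lower number a stronger inhibitor. Compound 3 has the highest number of the three, and both gaps are beyond the scatter: compound 2 lies closer to it and compound 1 furthest away, so compound 3 is the weakest inhibitor of this small set, though all three remain very strong inhibitors.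

Compound 4, `CC(C(=O)NCc1ccc(C(F)(F)F)cc1-c1cccnc1)c1ccc(NS(C)(=O)=O)c(F)c1`, has not yet been measured in this assay. It differs from compound 3 in one place: pyridin-3-yl in place of butylsulfanyl on an aromatic carbon. The three measured compounds share the same amide-linked core and differ only in what sits on the aromatic ring carrying the trifluoromethyl group. Compound 1, which carries a large ring-containing group there, gives 0.7 nM, the lowest number seen, which shows that a bulky ring in this position is well tolerated. No single-step comparison between measured compounds addresses this exact exchange, so the expectation rests on that broad tolerance.

The step from compound 3 to compound 4 is expected to be a 1.3-fold higher number from compound 3 to compound 4 (0.12 log units; within the scatter), that is, no change beyond the scatter. Compound 4 is therefore estimated at 2.5 nM, within a range of 0.8 nM to 8 nM.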

Compound 4, inhibition constant: 59.4 nM
Estimate against measurement, compound 4: 24-fold (1.38 log units) below, and the stated range ends below it.
By their numbers in this assay, from the lowest: compounds 1 and 2 (each within the scatter of the next); then compound 3; then compound 4.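

In this assay the exchange of butylsulfanyl for pyridin-3-yl on this aromatic carbon gives a 31-fold higher number from compound 3 to compound 4 (1.50 log units; beyond the scatter), the first single-place step read at this position, and it is a large one. The change in the number does not follow the counts that can be compared, as the two groups match in hydrogen-bond donors, hydrogen-bond acceptors and net charge and differ chiefly in that the entering group is an aromatic ring and the leaving group a chain. The earlier impression of broad tolerance therefore needs narrowing: compound 1 carries a large ring-containing group on this carbon and gives 0.7 nM, yet the pyridin-3-yl ring of compound 4 gives 59.4 nM, so a ring at this place is not by itself enough to keep the number low.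

No measurement shown gives a reason for this step. Still open, as far as these compounds go, is whether the ring nitrogen of pyridin-3-yl matters, which a phenyl group on the same carbon would address, and whether a benzyl group, with one carbon between the ring and the core, or a longer sulfur-linked chain would bring the number back down.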